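Compound 4 in the triazolylmethyl oxindole series: antiproliferative outlook

The source may hold more compounds than are shown below. What is called first, only, known or untested is meant among the compounds shown, and "the series" means these compounds.

Notes on the step from compound 3 to compound 4 in a functional assay on HepG2 cells (Homo sapiens) for antiproliferative activity, read by MTT assay, with a stated time of 48 h; on this read-out lower numbers stand for stronger inhibition and higher numbers for weaker inhibition.

Compound 1 `Cc1cccc(-n2nncc2CN2C(=O)C3(C(C#N)=C(N)Oc4c3c3nc5ccccc5nc3c3ccccc43)c3ccccc32)c1` carries a 3-methylphenyl group on the triazole. In this assay compound 1 returns only a limit, > 50000 nM. Compound 2 `Cc1cc(C)cc(-n2nncc2CN2C(=O)C3(C(C#N)=C(N)Oc4c3c3nc5ccccc5nc3c3ccccc43)c3ccccc32)c1` differs from compound 1 by methyl in place of hydrogen on an aromatic carbon. In this assay compound 2 likewise returns only a limit, > 50000 nM. The step that the two limits leave unreadable from compound 1 to compound 2 therefore cannot be read in either direction.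

Compound 3 `N#CC1=C(N)Oc2c(N)cc3nc4ccccc4nc3c2C12C(=O)N(Cc1cnnn1-c1ccc(Cl)cc1)c1ccccc12` bears a 4-chlorophenyl group on the triazole nitrogen and an amino group on the core. In this assay compound 3 also returns only a limit, > 50000 nM. Compound 3 thus stands where every measured member stands: the limit of > 50000 nM in this assay, at which 3 of the 3 values shown sit.

Compound 4 `N#CC1=C(N)Oc2c(N)cc3nc4ccccc4nc3c2C12C(=O)N(Cc1cnnn1-c1ccc([N+](=O)[O-])cc1[N+](=O)[O-])c1ccccc12` differs from compound 3 as follows: 2,4-dinitrophenyl in place of 4-chlorophenyl on an aromatic nitrogen. Among the measured compounds shown here, no measured step in this assay involves a change on this aromatic nitrogen, and the one step available, from compound 1 to compound 2, is unreadable, so nothing here gives a direction or size for the change. With all three members at the limit, compound 4 is expected to remain at or near that limit as well, a step that the limit leaves unreadable from compound 3 to compound 4. The estimate for compound 4 in this assay is 60000 nM, with a range from 15000 nM to 250000 nM, and most likely the assay again reports only a limit.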

Compound 4, half-maximal inhibitory concentration: 18400 nM
Compound 4: the middle estimate sits 3.3-fold (0.51 log units) above what was measured; the measured number falls inside the stated range.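

The read-out in this assay can move on this aromatic nitrogen: 2,4-dinitrophenyl in place of 4-chlorophenyl gives an at least 2.7-fold lower number from compound 3 to compound 4 (0.43 log units; beyond the scatter). Compound 3 holds only a limit, so this step gives a minimum size and no exact one. Compound 4 is the only member shown that returns a number rather than a limit, while the other three share a single limit: the limit of > 50000 nM in this assay, at which 3 of the 4 values shown sit.

The compounds shown do not separate the two nitro groups, and a 4-nitrophenyl or 2-nitrophenyl group on the same nitrogen, or a 4-aminophenyl group there, would show whether one substituent alone carries the step. On these data alone, the step from compound 1 to compound 2 cannot be read, and it also stays open whether 2,4-dinitrophenyl would give a number on the core of compound 1, so the change is known on one core only.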